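The compounds below may be only part of what the source reports. "The series", "measured", "known", "first", "only" and "open" are said of these compounds alone.

The account starts from compound 1 (`Cc1cn(C2CCN(Cc3cncc(Oc4cccc(Cl)c4)c3)CC2)c(=O)[nH]c1=O`), examined in an ADME assay on MRC5 cells (Homo sapiens) for cytotoxicity, read by fluorescence and resazurin assay, with a stated time of 3 days (on this read-out lower numbers stand for stronger inhibition and higher numbers for weaker inhibition), alongside two close relatives. In this assay compound 1 gives > 64000 nM as its result, and this is a limit of the assay, not a number. Compound 2 (`Cc1cn(C2CCN(Cc3cccc(Oc4cccc(Cl)c4)n3)CC2)c(=O)[nH]c1=O`) gives > 64000 nM as its result, which is again a limit. For compound 3 (`Cc1cn(C2CCN(Cc3cc(Oc4cc(Cl)cc(Cl)c4)ccn3)CC2)c(=O)[nH]c1=O`) the entry reads "not determined" (no result reported) and offers no comparison. Compound 1 therefore stands at the limit of > 64000 nM in this assay, at which 2 of the 3 values shown sit, and has no exact value to serve as a baseline.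

The next compound, compound 4 (`Cc1cn(C2CCN(Cc3cncc(Oc4ccccc4)c3)CC2)c(=O)[nH]c1=O`), differs from compound 1 in one place, with hydrogen in place of chloro on an aromatic carbon of a six-membered aromatic ring of carbon only, meta to a large group. The change, 3-chlorophenoxy to phenoxy, counts as hydrogen in place of chloro on an aromatic carbon and leaves the rest of the structure untouched.

For the measured compounds named here, no measured pair in this assay shows what this change does, so no step beyond the scatter is expected, in either direction. The estimated step of a number no higher from compound 1 to compound 4 (the limit leaves the size open) is expected to stay within the usual scatter. Compound 4 is estimated at 64000 nM with an expected range from 32000 nM to 128000 nM.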

Compound 4, half-maximal inhibitory concentration: > 64000 nM
Compound 4 ended at the assay's limit (the forecaster's own chance of this, stated with the estimate: 80%); the middle value sits exactly at the limit.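

In this assay compound 4 gives > 64000 nM as its result, which is a limit of the assay and not a number. No step can be read between compound 1 and compound 4, as both sit at the same limit: the limit of > 64000 nM in this assay, at which 3 of the 4 values shown sit. The compounds shown leave open what hydrogen in place of chloro does in this assay.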